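Nitro for methylsulfonyl on two cores

The compounds below may be only part of what the source reports. "The series", "measured", "known", "first", "only" and "open" are said of these compounds alone.

Values below come from an assay on THP-1 cells for antagonist activity at P2X purinoceptor 7 (Homo sapiens), read by ELISA, with a stated time of 30 min; a higher number here means a weaker inhibitor, a lower number a stronger inhibitor.

compound 1, `CS(=O)(=O)c1ccc(C(=O)N2CCC(n3cncc3-c3ccc(OS(=O)(=O)c4cccc5cnccc45)cc3)CC2)cc1`: 0.32 nM
compound 2, `O=C(c1ccc([N+](=O)[O-])cc1)N1CCC(n2cncc2-c2ccc(OS(=O)(=O)c3cccc4cnccc34)cc2)CC1`: 8.29 nM
compound 3, `CS(=O)(=O)c1ccc(C(=O)N2CCC(c3nc4cc(OS(=O)(=O)c5cccc6cnccc56)ccc4[nH]3)CC2)cc1`: 43 nM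

On the core of compound 1, the change nitro in place of methylsulfonyl on an aromatic carbon gave a 26-fold higher number from compound 1 to compound 2 (1.41 log units; beyond the scatter). Compound 3 carries a different core; how the two cores differ is not broken down here. Compound 3 shows the highest number of the three measured compounds, and its gap to compound 1 is the widest.

Compound 4, `O=C(c1ccc([N+](=O)[O-])cc1)N1CCC(c2nc3cc(OS(=O)(=O)c4cccc5cnccc45)ccc3[nH]2)CC1`, is not yet measured. It applies the same change to compound 3, (nitro in place of methylsulfonyl on an aromatic carbon), with the place described in the same words as on compound 1.

The expected step is a 19-fold higher number from compound 3 to compound 4 (1.27 log units; beyond the scatter), resting on a 26-fold higher number from compound 1 to compound 2 (1.41 log units; beyond the scatter); the different core of compound 3 leaves the transfer uncertain, so the range is set wide. For compound 4 in this assay the estimate is 800 nM, between 250 nM and 3000 nM.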

Compound 4, half-maximal inhibitory concentration: 17 nM
Compound 4: middle estimate off by 47-fold (1.67 log units), on the high side, and the stated range ends above it.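

In this assay, nitro in place of methylsulfonyl gave a 2.5-fold lower number from compound 3 to compound 4 (0.40 log units; beyond the scatter), opposite in direction to the step on the core of compound 1: the same change on two cores in this assay, a 26-fold higher number (1.41 log units; beyond the scatter) from compound 1 to compound 2 and a 2.5-fold lower number (0.40 log units; beyond the scatter) from compound 3 to compound 4, 66-fold (1.82 log units) apart, beyond the scatter of two such steps

So a result for this change on one core did not predict its direction or size on the other, and the two cores have to be treated separately for this swap. These two pairs do not show which feature of the cores lies behind the difference, and they give no rule for any further core.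

The compounds shown leave open whether a nitrile or a carboxylic acid on the same aromatic carbon would also behave differently on the two cores. They also leave open whether an amine there would follow either pair.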